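Unmeasured free-amide analogue of the rhodanine-bearing series

This account rests on a few compounds, and the source may have more. Where it says the series, first, only, none or still open, it means among the compounds named here.

Working notes. In a functional assay on HL-60 cells (Homo sapiens) for antiproliferative activity, read by MTT assay, with a stated time of 72 h (a higher number here means a weaker inhibitor, a lower number a stronger inhibitor), compound 1 `CN1C(=O)/C(=C/N2N=C(c3ccccc3)CC2c2ccccc2O)SC1=S` gives 2880 nM, the highest of the two numbers in hand. Compound 2 `O=C1/C(=C/N2N=C(c3ccccc3)CC2c2ccccc2O)SC(=S)N1c1cccnc1` gives 720 nM, a step of a 4.0-fold lower number from compound 1 to compound 2 (0.60 log units; beyond the scatter). For compound 3 `CCOC(=O)CCN1C(=O)/C(=C/N2N=C(c3ccccc3)CC2c2ccccc2O)SC1=S` only a limit of the assay is reported, > 10000 nM; this is the limit (the limit of > 10000 nM in this assay, at which 1 of the 3 values shown sits), so the steps of an at least 3.4-fold higher number from compound 1 to compound 3 (0.54 log units; beyond the scatter) and an at least 13-fold higher number from compound 2 to compound 3 (1.14 log units; beyond the scatter) are bounds, not numbers.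

Compound 4 `O=C1NC(=S)/C(=C/N2N=C(c3ccccc3)CC2c2ccccc2O)S1` is not yet measured. It differs from compound 1 by a group of 8 heavy atoms (4 carbon, 1 nitrogen, 1 oxygen, 2 sulfur; one five-membered non-aromatic ring with 2 hetero atoms) in place of a group of 9 heavy atoms (5 carbon, 1 nitrogen, 1 oxygen, 2 sulfur; one five-membered non-aromatic ring with 2 hetero atoms), on an amine nitrogen in a ring. The measured steps that touch this region all exchange the substituent on the amide-type nitrogen: pyridin-3-yl gave a lower number, (ethoxycarbonyl)methyl pushed the number beyond the limit. Neither is the present change, which leaves a hydrogen-bond donor on that nitrogen in the new ring, so a step larger than the scatter is not expected with confidence in this assay. Compound 4 is therefore estimated at 2500 nM, with a range of 700 nM to 9000 nM, a step of a 1.2-fold lower number from compound 1 to compound 4 (0.06 log units; within the scatter) from compound 1.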

Compound 4, half-maximal inhibitory concentration: 990 nM
Compound 4: middle estimate off by 2.5-fold (0.40 log units), on the high side; low and high end bracket the measured number.
By their numbers in this assay, from the lowest: compounds 2 and 4 (each within the scatter of the next); then compound 1. At a limit, above all of these: compound 3.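

In this assay, within the data shown here, unlike the earlier steps, which only exchanged the substituent on the amide-type nitrogen, this change replaces the whole five-membered group on the amine nitrogen in a ring and gives a 2.9-fold lower number from compound 1 to compound 4 (0.46 log units; beyond the scatter). The position therefore responds to a change in the group itself, and a number below that of compound 1 does not depend on a pyridin-3-yl substituent. The entering group has 1 hydrogen-bond donor where the leaving group has 0, but nothing measured here accounts for the step.

The exchange of the whole group leaves the contribution of the donor apart from the rest of the change unresolved. Also open, going by these compounds, is how a carboxylic acid in place of the ethyl ester of 2-(ethoxycarbonyl)ethyl, or a benzyl group on the amide-type nitrogen, would read in this assay.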